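Halogen swap on the arylpiperazine of a xanthine sulfonamide

The source may hold more compounds than are shown below. What is called first, only, known or untested is meant among the compounds shown, and "the series" means these compounds.

Among the measured compounds shown here, compound 2 `CCCn1c(=O)[nH]c2nc(-c3ccc(S(=O)(=O)N4CCN(c5ccc(I)cc5)CC4)cc3)[nH]c2c1=O` gives 24% in an assay on CHO cells for displacement of a labelled ligand from adenosine receptor A1 (Homo sapiens), read by scintillation counting, with a stated time of 90 min, tested at 1 uM, in the presence of a further agent that is not named here (on this read-out lower numbers stand for less inhibition and higher numbers for more inhibition at the one concentration tested (going by the name of the read-out)), the highest of the two numbers known; compound 1 `CCCn1c(=O)[nH]c2nc(-c3ccc(S(=O)(=O)N4CCN(c5ccc(C)cc5)CC4)cc3)[nH]c2c1=O` gives 12%, and the step of a number 12 percentage points higher from compound 1 to compound 2 (beyond the scatter) lies beyond the scatter. Compound 3 `CCCn1c(=O)[nH]c2nc(-c3ccc(S(=O)(=O)N4CCN(c5ccccc5Cl)CC4)cc3)[nH]c2c1=O` differs from compound 2 by 2-chlorophenyl in place of 4-iodophenyl on an amine nitrogen in a ring. For the measured compounds named here, only the step from compound 1 to compound 2 bears on this, and it changed a different substituent on the same aryl ring, so the guidance is loose. Compound 3 is therefore expected to show a number 6 percentage points lower from compound 2 to compound 3 (within the scatter), a change of little size. The estimate for compound 3 is 18%, within 5% to 32%.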

Compound 3, a percentage reported as inhibition, at one concentration (the size of the read-out at that concentration, not a potency): 25%
Compound 3: the middle estimate sits 7 percentage points below what was measured, within the range that was stated.
By their numbers in this assay, from the lowest: compound 1; then compounds 2 and 3 (each within the scatter of the next).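

In this assay the exchange on the amine nitrogen in the ring gives a number 1 percentage points higher from compound 2 to compound 3 (within the scatter) and so does not separate 2-chlorophenyl from 4-iodophenyl at this position. Set against 4-methylphenyl, 2-chlorophenyl gives a number 13 percentage points higher from compound 1 to compound 3 (beyond the scatter) and so compound 1 is the one of the three that stands apart. No measurement at hand explains either step.

Compound 2 and compound 3 differ in both the halogen and its place on the ring, so the two cannot be separated here. From the compounds shown here alone, how a methoxy group on that aryl ring or a benzyl group in its stead would read stays open.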